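The source may report more compounds than this note shows. Statements on the series, on what has been measured and on what is new or still open speak of the compounds shown alone.

In an ADME assay on cells (T-cell, Mus musculus, strain BALB/c) for cytotoxicity, read by MTT assay, with a stated time of 48 h (a higher number here means that more compound is tolerated, a lower number that less compound is tolerated), three compounds have been measured:

compound 1 `COC(=O)c1cc(F)ccc1OC(=O)COc1cc(O)c2c(=O)cc(-c3ccccc3)oc2c1` gives 389000 nM
compound 2 `COC(=O)c1cccc(C)c1OC(=O)COc1cc(O)c2c(=O)cc(-c3ccccc3)oc2c1` gives 299000 nM
compound 3 `COC(=O)c1ccc(Br)cc1OC(=O)COc1cc(O)c2c(=O)cc(-c3ccccc3)oc2c1` gives 326000 nM

Compound 3 stands second highest of these three numbers. Its nearest neighbour is compound 2, with a 1.1-fold higher number from compound 2 to compound 3 (0.04 log units; within the scatter); the furthest is compound 1, with a 1.2-fold lower number from compound 1 to compound 3 (0.08 log units; within the scatter). All three compounds share one core and differ only in the aryl group on the oxygen next to the carbonyl group, and every step among them stays within the scatter: a 1.3-fold lower number from compound 1 to compound 2 (0.11 log units; within the scatter), a 1.2-fold lower number from compound 1 to compound 3 (0.08 log units; within the scatter), a 1.1-fold higher number from compound 2 to compound 3 (0.04 log units; within the scatter).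

Compound 4 `COC(=O)c1c(Cl)cccc1OC(=O)COc1cc(O)c2c(=O)cc(-c3ccccc3)oc2c1` carries the same kind of change at the same place: a group of 11 heavy atoms (8 carbon, 2 oxygen, 1 chlorine; one six-membered aromatic ring of carbon only) in place of a group of 11 heavy atoms (8 carbon, 2 oxygen, 1 bromine; one six-membered aromatic ring of carbon only), on an oxygen next to a carbonyl group. The three measured steps all bear on it, since each swaps one such aryl group for another on the same oxygen, and none moved the number beyond the scatter. The expected step is therefore a 1.0-fold lower number from compound 3 to compound 4 (0.01 log units; within the scatter), no more than the scatter in either direction. Compound 4 is estimated at 320000 nM, with a range from 200000 nM to 500000 nM.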

Compound 4, half-maximal cytotoxic concentration: 366000 nM
Compound 4: the middle estimate sits 1.1-fold (0.06 log units) below what was measured; measured number inside the range.
By their numbers in this assay, from the lowest: compounds 2, 3, 4 and 1 (each within the scatter of the next).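

In this assay, the 3-chloro-2-(methoxycarbonyl)phenyl group on the oxygen next to a carbonyl group falls in with the earlier aryl groups: the steps are a 1.1-fold higher number from compound 3 to compound 4 (0.05 log units; within the scatter) and a 1.2-fold higher number from compound 2 to compound 4 (0.09 log units; within the scatter) and a 1.1-fold lower number from compound 1 to compound 4 (0.03 log units; within the scatter) and none of them leaves the scatter. With chlorine added to the fluorine, bromine and all-carbon variants, all four compounds now lie within the scatter of one another, so at this position in this assay the swaps among these four aryl groups have not separated any compound from the rest. Nothing available explains this result or bears on it.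

Every aryl group shown keeps its methoxycarbonyl group, so it remains open whether a carboxylic acid or an amide in its place would move the number beyond the scatter. Going by these compounds, an amine on that ring, or a longer chain in place of the aryl group, is equally open.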